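The source may hold more compounds than are shown below. What is called first, only, known or untested is meant among the compounds shown, and "the series" means these compounds.

Compound 1 `CCOC(=O)CC(=O)OCC1Oc2ccc([C@H]3Oc4cc(O)cc(O)c4C(=O)[C@@H]3O)cc2OC1c1ccc(O)c(OC)c1` was tested in a functional assay, read by spectrophotometry, with a stated time of 30 min (a lower number here means that less compound is needed, a higher number that more compound is needed for the effect), where compound 1 gives 101000 nM. Among the three measured compounds this is the second highest number: compound 3 `COc1cc(C2Oc3cc([C@H]4Oc5cc(O)cc(O)c5C(=O)[C@@H]4O)ccc3OC2COC(=O)c2cc(OC)c(OC)c(OC)c2)ccc1O` gives 94800 nM, a difference within the scatter, while compound 2 `COc1cc(C2Oc3cc([C@H]4Oc5cc(O)cc(O)c5C(=O)[C@@H]4O)ccc3OC2COC(=O)c2cc([N+](=O)[O-])cc([N+](=O)[O-])c2)ccc1O` gives 205000 nM, the step being a 2.0-fold higher number from compound 1 to compound 2 (0.31 log units; beyond the scatter). Compound 4 `COc1cc(C2Oc3cc([C@H]4Oc5cc(O)cc(O)c5C(=O)[C@@H]4O)ccc3OC2COC(=O)c2ccc(OC)c(OC)c2)ccc1O` has not yet been measured; it differs from compound 1 by 3,4-dimethoxyphenyl in place of (ethoxycarbonyl)methyl on a carbonyl carbon. For the measured compounds named here, the closest precedent is the step of a 1.1-fold lower number from compound 1 to compound 3 (0.03 log units; within the scatter), where another aromatic ring bearing methoxy groups replaced the same group and the number hardly moved. The step of a 2.0-fold higher number from compound 1 to compound 2 (0.31 log units; beyond the scatter) shows that a different aromatic ring can raise the number modestly. On balance no change beyond the scatter is expected, so the estimated step is a 1.0-fold lower number from compound 1 to compound 4 (0.00 log units; within the scatter). For compound 4 the expected value is therefore 100000 nM, within a range from 50000 nM to 200000 nM.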

Compound 4, half-maximal effective concentration: 77000 nM
The estimate for compound 4 lay 1.3-fold (0.11 log units) above the measured number; measured number inside the range.
By their numbers in this assay, from the lowest: compounds 4, 3 and 1 (each within the scatter of the next); then compound 2.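

In this assay, compound 4 cannot be told apart from compound 1 (a 1.3-fold lower number from compound 1 to compound 4 (0.12 log units; within the scatter)), so on this carbonyl carbon, 3,4-dimethoxyphenyl and the open-chain (ethoxycarbonyl)methyl group read alike. It also cannot be told apart from compound 3 (a 1.2-fold lower number from compound 3 to compound 4 (0.09 log units; within the scatter)), which shows that hydrogen in place of methoxy on the aromatic ring makes no readable difference here. Compound 2, with its 3,5-dinitrophenyl group, stays apart (a 2.7-fold lower number from compound 2 to compound 4 (0.43 log units; beyond the scatter)). On these data alone, whether an amine or a carboxylic acid at this place would move the number remains open. Nothing available explains why these numbers fall as they do.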